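Difluoroethoxy for trifluoromethyl on the shared core

The compounds below may be only part of what the source reports. "The series", "measured", "known", "first", "only" and "open" are said of these compounds alone.

Measured compounds:
- compound 1, `N#Cc1cnc(NCc2cnccc2C(F)(F)F)cc1N[C@H]1CC[C@@H](O)CC1`: 4500 nM
- compound 2, `N#Cc1cnc(NCc2cncnc2C(F)(F)F)cc1N[C@H]1CC[C@@H](O)CC1`: 450 nM

In an assay on isolated protein for inhibition of protein kinase C delta type (Homo sapiens), read by TR-FRET, with a stated time of 2 h (on this read-out higher numbers stand for weaker inhibition and lower numbers for stronger inhibition), compound 2 gives the lowest of the two numbers; compound 1 gives a higher number, a gap beyond the scatter. Compound 3, `N#Cc1cnc(NCc2cncnc2OCC(F)F)cc1N[C@H]1CC[C@@H](O)CC1`, is not yet measured. It differs from compound 2 by 2,2-difluoroethoxy in place of trifluoromethyl on an aromatic carbon. Going by the values given here, no step of this kind is known among the measured compounds, so the direction rests on judgement alone. A modest loss beyond the scatter is expected, a 2.2-fold higher number from compound 2 to compound 3 (0.35 log units; beyond the scatter), in this assay. Compound 3 is therefore estimated at 1000 nM, in the range 250 nM to 4000 nM.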

Compound 3, half-maximal inhibitory concentration: 90 nM
For compound 3 the middle estimate is 11-fold (1.05 log units) above the measured one, outside the stated range (below it).
By their numbers in this assay, from the lowest: compound 3; then compound 2; then compound 1.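

In this assay the change to 2,2-difluoroethoxy in place of trifluoromethyl gives a 5.0-fold lower number from compound 2 to compound 3 (0.70 log units; beyond the scatter) and shows that this aromatic carbon, next to the ring nitrogen, can take an oxygen-linked chain with a gain in inhibition. The earlier compounds shown here both carried trifluoromethyl here, so they showed nothing about what this position accepts. Nothing available explains the gain.

From the compounds shown here alone, whether the gain goes with the oxygen link or with the fluorine atoms stays open. A plain ethoxy group or a longer chain at this carbon would bear on that question.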